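The source may hold more compounds than are shown below. What is called first, only, known or untested is meant among the compounds shown, and "the series" means these compounds.

Measured in a functional assay on a cell-free system (plasma, Homo sapiens), with a stated time of 3 min; a lower number here means a stronger inhibitor, a higher number a weaker inhibitor:
- Compound 1 `CC(C)(C)C[C@@H](O)C(=O)N1N=CC[C@H]1C(=O)NCc1cc(Cl)ccc1-n1cnnn1`: 590 nM
- Compound 2 `CC(C)(C)C[C@@H](O)C(=O)N1C[C@@H]2C[C@@H]2[C@H]1C(=O)NCc1cc(Cl)ccc1-n1cnnn1`: 910 nM

Compound 2, at 910 nM, and compound 1, at 590 nM, lie within the scatter of each other. Compound 3 `O=C(NCc1cc(Cl)ccc1-n1cnnn1)[C@@H]1[C@H]2C[C@H]2CN1C(=O)[C@H](O)Cn1cccn1` carries 1H-pyrazol-1-yl in place of tert-butyl on a saturated chain carbon, two bonds along the chain from a carbonyl carbon and an oxygen on a saturated carbon. Among the compounds with values here, no measured pair shows this change, so the expectation rests on the structural change alone: a moderate move towards weaker inhibition, somewhat beyond the scatter. The expected step is a 2.0-fold higher number from compound 2 to compound 3 (0.30 log units; within the scatter). For compound 3 the estimated value is 1800 nM, with an expected range of 500 nM to 6000 nM.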

Compound 3, half-maximal inhibitory concentration: 1800 nM
Estimate against measurement, compound 3: no gap at the digits printed; low and high end bracket the measured number.
By their numbers in this assay, from the lowest: compounds 1, 2 and 3 (each within the scatter of the next, the first and the last beyond it).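

In this assay, 1H-pyrazol-1-yl in place of tert-butyl gives a 2.0-fold higher number from compound 2 to compound 3 (0.30 log units; within the scatter), so at this saturated chain carbon, a five-membered aromatic ring with 2 hetero atoms and a purely carbon group with no ring cannot be told apart. The earlier compounds shown here kept tert-butyl here and showed nothing about this place. Nothing measured here accounts for the result.

Going by these compounds, whether an amine or a carboxylic acid on this chain carbon would stay within the scatter of compound 2 remains open. So does the effect of a longer chain carrying the 1H-pyrazol-1-yl group.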